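The source may hold more compounds than are shown below. What is called first, only, known or untested is meant among the compounds shown, and "the series" means these compounds.

Working notes on the pyrazolyl chalcone series, read in a functional assay on SK-OV-3 cells (Homo sapiens) for inhibition, read by sulforhodamine B assay, with a stated time of 48 h; a higher number here means a weaker inhibitor of growth, a lower number a stronger inhibitor of growth.

Three members of the series have numbers. Compound 1 `COc1cc(-c2cc(/C=C/C(=O)c3ccc(N)cc3)[nH]n2)cc(OC)c1OC` gives 2990 nM. Compound 2 `COc1cc(-c2cc(/C=C/C(=O)c3ccc(Cl)c(Cl)c3)[nH]n2)cc(OC)c1OC` gives 4190 nM. Compound 3 `COc1ccc(-c2cc(/C=C/C(=O)c3cc(OC)c(OC)c(OC)c3)[nH]n2)cc1OC`, which carries the trimethoxyphenyl group on the carbonyl carbon, gives 5470 nM. Compound 2 stands second highest of the three, with compound 3 nearest and compound 1 furthest; both gaps lie within the scatter, so no order among the three can be claimed.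

Among the compounds with values here, the only single-point step measured so far is a 1.4-fold higher number from compound 1 to compound 2 (0.15 log units; within the scatter), a change on the carbonyl carbon that did not move the number beyond the scatter.

Compound 4 `COc1ccc(C(=O)/C=C/c2cc(-c3cc(OC)c(OC)c(OC)c3)n[nH]2)cc1` is not yet measured. It differs from compound 2 by 4-methoxyphenyl in place of 3,4-dichlorophenyl on a carbonyl carbon. This is again a swap of the aryl group on the carbonyl carbon, the same place as the step from compound 1 to compound 2, and compound 3 with a third aryl group at that carbon also sits within the scatter of compound 2. Little movement is therefore expected for compound 4: an estimated step of a 1.1-fold higher number from compound 2 to compound 4 (0.03 log units; within the scatter), in no clear direction. Compound 4 is estimated at 4500 nM, within a range of 2000 nM to 10000 nM.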

Compound 4, concentration for 50% growth inhibition: 3990 nM
For compound 4 the middle estimate is 1.1-fold (0.05 log units) above the measured one, within the range that was stated.
By their numbers in this assay, from the lowest: compounds 1, 4, 2 and 3 (each within the scatter of the next).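

In this assay, 4-methoxyphenyl in place of 3,4-dichlorophenyl on the carbonyl carbon gives a 1.1-fold lower number from compound 2 to compound 4 (0.02 log units; within the scatter) and so stays within the scatter, although the entering group has a hydrogen-bond acceptor and the leaving group has none. Methoxy in place of amino on an aromatic carbon gives a 1.3-fold higher number from compound 1 to compound 4 (0.13 log units; within the scatter) and also stays within the scatter, so the amino group is not required for a number in this range. Nothing measured here explains why these changes leave the number within the scatter.

The compounds shown leave open whether any change at this position can move the number beyond the scatter. A carboxylic acid on the aryl ring, or a saturated alkyl chain in place of that ring on the carbonyl carbon, would test this more severely than the aryl swaps so far.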